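The compounds below may be only part of what the source reports. "The series", "measured", "known", "first", "only" and "open" are said of these compounds alone.

Measured so far:
compound 1, `O=C(Nc1cccc(-n2cc(-c3ccncc3)c(-c3ccc(Cl)c(O)c3)n2)c1)Nc1ccc(Cl)c(Cl)c1`: > 32500 nM
compound 2, `COc1cc(-c2nn(-c3cccc(NC(=O)Nc4ccc(Cl)c(C(F)(F)F)c4)c3)cc2-c2ccncc2)ccc1Cl`: 19100 nM

Among the measured compounds shown here, in a functional assay on M14 cells (Homo sapiens) for inhibition, read by sulforhodamine B assay, with a stated time of 48 h (a higher number here means that more compound is tolerated, a lower number that less compound is tolerated), compound 2 gives 19100 nM, the only plain number among the two values shown. For compound 1 the read-out is a limit of the assay, > 32500 nM, so compound 1 sits at the limit of > 32500 nM in this assay, at which 1 of the 2 values shown sits, and no number is known for it. For the measured compounds named here, no pair of measured compounds differs in a single place, so no measured step can be drawn from these two.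

Compound 3, `O=C(Nc1cccc(-n2cc(-c3ccncc3)c(-c3ccc(Cl)c(O)c3)n2)c1)Nc1ccc(Cl)c(C(F)(F)F)c1`, is the next compound to be measured in this assay. Compound 3 differs from compound 2 by hydrogen in place of methyl on an oxygen on an aromatic ring; the same difference, cut one bond further out, reads methoxy to hydroxy, or 4-chloro-3-methoxyphenyl to 4-chloro-3-hydroxyphenyl. Compound 3 thus carries the hydroxy group of compound 1 together with the urea terminus of compound 2. Compound 1, which shares that hydroxy group, gives only a limit in this assay, and that points the expectation for compound 3 upward rather than down. The expected step from compound 2 to compound 3 is a 1.5-fold higher number from compound 2 to compound 3 (0.17 log units; within the scatter), a modest rise, with a fair chance that the assay again reports only a limit. Compound 3 is therefore estimated at 28000 nM, within 12000 nM to 60000 nM.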

Compound 3, concentration lethal to 50% of the cells: > 32500 nM
Compound 3 gave a limit, no number; the forecaster's own chance of this, stated with the estimate: 40%; middle value at least 1.1-fold (0.06 log units) from the limit.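

In this assay, among the compounds shown here, the change from methoxy to hydroxy on the aromatic ring gives the first readable step: an at least 1.7-fold higher number from compound 2 to compound 3 (0.23 log units; that floor lies within the scatter). From the compounds shown here alone, compound 3 gives > 32500 nM, a limit of the assay and not a number, so the step is only a floor and the true size of the change remains unknown. Compound 1 and compound 3 both carry the hydroxy group and end at the same limit, with either chloro or trifluoromethyl on the aromatic carbon, so the step between them cannot be read: the limit of > 32500 nM in this assay, at which 2 of the 3 values shown sit.

Going by these compounds, how far compound 1 and compound 3 lie past this limit remains open, and with it whether the change from methoxy to hydroxy moves the read-out beyond the usual scatter at all. Also open, on these data alone, is how a longer ether such as ethoxy, or an amine in place of the methoxy group, would read in this assay, and whether a plain number can be obtained for any compound that keeps a free hydroxy group.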